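Fluoro for hydroxy on the core: cytotoxicity expected unchanged

A few compounds are considered here, and "the series" means these few. Any claim that something is new, unique, unknown or untested is made for them only; others in the source may bear on it.

Compound 1 `COc1ccc([C@H]2CC(C)(O)[C@@H]3CC[C@@H](C)C[C@H]3O2)c(OC)c1` is known in an ADME assay on MDCK cells (Canis lupus familiaris) for cytotoxicity, read by MTT assay, with a stated time of 48 h (a lower number here means that less compound is tolerated, a higher number that more compound is tolerated), only through a limit. In this assay compound 1 gives > 937000 nM, a limit of the assay and not a number. Compound 2 `COc1cc(OC)c([C@H]2CC(C)(O)[C@@H]3CC[C@@H](C)C[C@H]3O2)cc1OC`, which carries a methoxy in place of hydrogen on an aromatic carbon, also stands at a limit. In this assay compound 2 gives > 857000 nM, again a limit rather than a number. Going by the values given here, the single measured step, a step that the two limits leave unreadable from compound 1 to compound 2, is therefore unreadable; its ends sit at the limit of > 937000 nM in this assay, at which 1 of the 2 values shown sits, and (the limit of > 857000 nM in this assay, at which 1 of the 2 values shown sits).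

Compound 3 `COc1ccc([C@H]2CC(C)(F)[C@@H]3CC[C@@H](C)C[C@H]3O2)c(OC)c1` differs from compound 1 by fluoro in place of hydroxy on a saturated ring carbon, a fluoro in place of hydroxy on a saturated ring carbon of the shared core. Among the compounds with values here, no measured step touches this part of the core, and the one step that exists, an aromatic methoxy change, yields no readable size. Since both measured values rest at limits, no movement beyond the scatter in this assay is expected. Compound 3 is estimated at 900000 nM, with a range from 300000 nM to 2000000 nM. The implied step, an at least 1.0-fold lower number from compound 1 to compound 3 (0.01 log units; that floor lies within the scatter), is expected to remain within the scatter.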

Compound 3, half-maximal cytotoxic concentration: 379000 nM
For compound 3 the middle estimate is 2.4-fold (0.38 log units) above the measured one; the range from low to high includes it.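

Fluoro in place of hydroxy on a saturated ring carbon of the shared core gives the only readable step in this assay so far: an at least 2.4-fold lower number from compound 1 to compound 3 (0.39 log units; beyond the scatter). Compound 3 gives 379000 nM, a measured number that places the tolerated concentration inside the range of the assay, so this position on the core can change the read-out, something the aromatic methoxy change could not show, as its step cannot be read. The true size of the new step remains unknown and only its floor is given, because compound 1 stands at a limit of the assay: the limit of > 937000 nM in this assay, at which 1 of the 3 values shown sits.

What the compounds shown leave open is whether the step follows from the loss of the hydroxy or from the arrival of the fluoro, and how an amine or a plain hydrogen on the same carbon would stand in this assay. As far as these compounds go, it is also open whether fluoro in place of hydroxy would give a step of similar size on the core of compound 2, with its additional methoxy.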